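Diaryl urea series: trifluoromethyl placement on the terminal phenyl

A few compounds are considered here, and "the series" means these few. Any claim that something is new, unique, unknown or untested is made for them only; others in the source may bear on it.

Compounds measured so far:
compound 1 `COc1cc2cc(Oc3ccc(NC(=O)Nc4ccccc4)cc3)c(C)nc2cc1OC` — 67.2%
compound 2 `COc1cc2cc(Oc3ccc(NC(=O)Nc4ccc(C(F)(F)F)cc4)cc3)c(C)nc2cc1OC` — 63.2%

In a functional assay on NCI-H522 cells (Homo sapiens) for inhibition, read by sulforhodamine B assay, with a stated time of 48 h, tested at 10 uM (on this read-out lower numbers stand for a stronger effect and higher numbers for a weaker effect at the one concentration tested), compound 1 gives 67.2% and compound 2 gives 63.2%. Compound 2 stands lowest of the two numbers; its nearest neighbour is compound 1, and the gap between the two is within the scatter. Going by the values given here, the one measured step, a number 4 percentage points lower from compound 1 to compound 2 (within the scatter), is all that is available and is itself within the scatter.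

Compound 3 `COc1cc2cc(Oc3ccc(NC(=O)Nc4cccc(C(F)(F)F)c4)cc3)c(C)nc2cc1OC` has not been measured. It differs from compound 2 by 3-(trifluoromethyl)phenyl in place of 4-(trifluoromethyl)phenyl on an amide-type nitrogen. Among the compounds with values here, no measured step compares the two trifluoromethyl-bearing phenyl groups with each other; the only related step, a number 4 percentage points lower from compound 1 to compound 2 (within the scatter), set trifluoromethyl against hydrogen and gave no change beyond the scatter. On that basis no step beyond the scatter is expected in this assay, and the expected step is a number 0.2 percentage points lower from compound 2 to compound 3 (within the scatter). Compound 3 is therefore estimated at 63%, with a range from 50% to 76%.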

Compound 3, a percentage reported as activity, at one concentration (the size of the read-out at that concentration, not a potency): -17.4%
For compound 3 the middle estimate is 80.4 percentage points above the measured one, outside the stated range (below it).
By their numbers in this assay, from the lowest: compound 3; then compounds 2 and 1 (each within the scatter of the next).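

In this assay, the placement of the trifluoromethyl group on the terminal phenyl matters, and not merely its presence: with the same atoms joined differently, 3-(trifluoromethyl)phenyl in place of 4-(trifluoromethyl)phenyl on the amide-type nitrogen gives a number 80.6 percentage points lower from compound 2 to compound 3 (beyond the scatter). Against the unsubstituted phenyl, the 3-(trifluoromethyl)phenyl change gives a number 84.6 percentage points lower from compound 1 to compound 3 (beyond the scatter), whereas the 4-(trifluoromethyl)phenyl change gave only a number 4 percentage points lower from compound 1 to compound 2 (within the scatter), so the earlier step cannot be taken to describe trifluoromethyl in general on this ring. No available measurement bears on why the two placements differ so widely.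

It remains open whether the large step belongs to trifluoromethyl itself or would also appear with another group, as in 3-chlorophenyl, 3-methoxyphenyl or 3-cyanophenyl on the same nitrogen. this assay reports the size of the effect at one concentration in one cell line, so the compounds shown also leave open how the effect of compound 3 would compare at other concentrations or whether it extends to other cell lines.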